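Urea alkyl size and cytotoxicity in three measured compounds

This account rests on a few compounds, and the source may have more. Where it says the series, first, only, none or still open, it means among the compounds named here.

Values in a functional assay on MGC-803 cells (Homo sapiens) for cytotoxicity, read by MTT assay, with a stated time of 72 h; a lower number here means a stronger inhibitor, a higher number a weaker inhibitor:
Compound 1 `CC(C)NC(=O)N1CCN(C(=S)SCc2cn(Cc3ccccc3F)nn2)CC1`: 1620 nM
Compound 2 `CC(C)(C)NC(=O)N1CCN(C(=S)SCc2cn(Cc3ccccc3F)nn2)CC1`: 40700 nM
Compound 3 `CCNC(=O)N1CCN(C(=S)SCc2cn(Cc3cc(OC)c(OC)c(OC)c3)nn2)CC1`: 101000 nM

Compound 2 carries methyl in place of hydrogen on a saturated chain carbon bound to an amide-type nitrogen and two saturated chain carbons relative to compound 1, and the step is a 25-fold higher number from compound 1 to compound 2 (1.40 log units; beyond the scatter). Compound 4 `COc1cc(Cn2cc(CSC(=S)N3CCN(C(=O)NC(C)C)CC3)nn2)cc(OC)c1OC` is not yet measured; relative to compound 3 it carries methyl in place of hydrogen on a saturated chain carbon bound to an amide-type nitrogen and a saturated chain carbon. This is the same kind of change, not the same: in the earlier pair the carbon is bound to an amide-type nitrogen and two saturated chain carbons, in the new pair to an amide-type nitrogen and a saturated chain carbon. The difference between the core of compound 1 and the core of compound 3 is not broken down here. Compound 3 stands highest of the three in this assay. The step from compound 1 to compound 2 was large: a 25-fold higher number from compound 1 to compound 2 (1.40 log units; beyond the scatter). Accordingly, a weakening is expected from compound 3 to compound 4, but a smaller one, estimated as a 1.5-fold higher number from compound 3 to compound 4 (0.17 log units; within the scatter), as the place differs. Compound 4 is expected at 150000 nM, within 40000 nM to 500000 nM.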

Compound 4, half-maximal inhibitory concentration: > 128000 nM
Compound 4: only a limit was reported (the forecaster's own chance of this, stated with the estimate: 30%); the middle value lies beyond the limit too.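

In this assay compound 4 gives > 128000 nM, which is a limit of the assay and not a number. The added methyl therefore reads only as an at least 1.2-fold higher number from compound 3 to compound 4 (0.10 log units; that floor lies within the scatter), so the change on the core of compound 3 has a floor but no size, and that floor does not itself establish a weakening. Set beside the step on the core of compound 1, this neither confirms nor rules out that the change carries over with the same size: the same change on two cores in this assay, a 25-fold higher number (1.40 log units; beyond the scatter) from compound 1 to compound 2 and an at least 1.2-fold higher number (0.10 log units; that floor lies within the scatter) from compound 3 to compound 4; the limit leaves it open whether they differ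

As far as these compounds go, how far compound 4 lies past the limit stays unknown, and the limit also bounds this small set: the limit of > 128000 nM in this assay, at which 1 of the 4 values shown sits. Also open is whether a cyclopropyl or a straight propyl on the urea nitrogen would give a readable step on either core.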